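The source may hold more compounds than are shown below. What is called first, only, known or untested is meant among the compounds shown, and "the series" means these compounds.

Measured so far in a functional assay on CHO-K1 cells for agonist activity at Glucose-dependent insulinotropic receptor (Homo sapiens), read by HTRF and cAMP accumulation, with a stated time of 30 min; a higher number here means a larger maximal response, a lower number a smaller maximal response:
compound 1 `CC(C)(C)OC(=O)N1CCC(OCCNc2ccc3c(c2)CCS3(=O)=O)CC1` gives 33%
compound 2 `CC(C)(C)OC(=O)N1CCC(CCCNc2ccc3c(c2)CCCCC3=O)CC1` gives 38%
compound 3 `CCc1cnc(N2CCC(CCCNc3ccc4c(c3)OCC4=O)CC2)nc1` gives 115%

Compound 3 stands highest of the three in this assay; the gaps to compound 2, the nearest, and to compound 1, the furthest, are both beyond the usual scatter, so compound 3 is the strongest of the three on this read-out. Compound 4 `CC(C)c1nnc(N2CCC(CCCNc3ccc4c(c3)OCC4=O)CC2)o1` is the unmeasured compound. Relative to compound 3 it differs in one place: 5-isopropyl-1,3,4-oxadiazol-2-yl in place of 5-ethylpyrimidin-2-yl on an amine nitrogen in a ring. The rest of the molecule is unchanged. Within the data shown here, no step between measured compounds bears on an exchange of this kind; compounds 1 and 2 differ from compound 3 in several places at once and offer no guide to it. With the remainder of compound 3 kept, the maximal response in this assay is expected to stay near that of compound 3, with at most a modest downward step, not clearly beyond the scatter. The estimate for compound 4 is 100%, range 70% to 125%. This corresponds to an expected step of a number 15 percentage points lower from compound 3 to compound 4 (beyond the scatter).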

Compound 4, largest response reached (Emax), in percent of the reference or control that the assay uses: 85%
Compound 4: the middle estimate sits 15 percentage points above what was measured, within the range that was stated.
By their numbers in this assay, from the lowest: compounds 1 and 2 (each within the scatter of the next); then compound 4; then compound 3.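

In this assay, among these compounds, placing 5-isopropyl-1,3,4-oxadiazol-2-yl in place of 5-ethylpyrimidin-2-yl on the amine nitrogen in a ring gives a number 30 percentage points lower from compound 3 to compound 4 (beyond the scatter) as the first single-place reading at this position. The maximal response therefore responds to this exchange, although compound 4 still reaches 85% with a five-membered aromatic ring with 3 hetero atoms at this place. Nothing in the data shown gives a reason for the step.

The exchange alters the aromatic ring and its alkyl group together, so the share of each in the step remains unresolved. As far as these compounds go, a 5-isopropylpyrimidin-2-yl or 5-ethyl-1,3,4-oxadiazol-2-yl group on the same nitrogen would separate the two, while the effect of an unsubstituted pyrimidin-2-yl group at this position also remains open.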